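This account rests on a few compounds, and the source may have more. Where it says the series, first, only, none or still open, it means among the compounds named here.

Of the compounds shown here, three have so far been measured in an assay on isolated protein for inhibition of Aromatase (Homo sapiens), read by fluorescence, tested at 1 uM; a lower number here means less inhibition, a higher number more inhibition at the concentration tested (going by the name of the read-out). Compound 1 `N#Cc1ccc(Oc2cccnc2)cc1NCc1ccccc1` gives 58%. Compound 2 `N#Cc1ccc(Oc2cccnc2)c(Oc2cccnc2)c1` gives 82%, and compound 3 `N#Cc1ccc(-n2ccc3ccncc32)cc1` gives 94%. Compound 1 therefore stands lowest of the three: compound 2 is nearest to it, by a gap beyond the usual scatter, and compound 3 is furthest, also beyond the scatter. The piece now turns to compound 4 `N#Cc1ccc(Oc2cccnc2)cc1NC1CCCCC1`, which has not yet been tested in this assay. It differs from compound 1 in a single place: cyclohexyl in place of benzyl on a nitrogen on an aromatic ring. Within the data shown here, no pair of measured compounds differs in just this way, so there is no measured step to lean on; compounds 2 and 3 differ from compound 1 elsewhere and show only that the spread across the set is wide. The change here is modest, so the expected step is a number 8 percentage points lower from compound 1 to compound 4 (within the scatter), within the scatter or a little downward. Compound 4 is accordingly estimated at 50%, with a range from 25% to 75%.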

Compound 4, a percentage reported as inhibition, at one concentration (the size of the read-out at that concentration, not a potency): 33%
Compound 4: the middle estimate sits 17 percentage points above what was measured; measured number inside the range.
By their numbers in this assay, from the lowest: compound 4; then compound 1; then compound 2; then compound 3.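

In this assay, among these compounds, the group on a nitrogen on an aromatic ring proves to matter: cyclohexyl in place of benzyl gives a number 25 percentage points lower from compound 1 to compound 4 (beyond the scatter), the first measured step at this place. For this pair, then, a six-membered non-aromatic ring of carbon only does not hold the inhibition seen with benzyl, although the change looks modest on paper and also removes one carbon. Nothing at hand says why the number falls.

Since the ring and the carbon count change together, the two cannot yet be told apart, and a cyclohexylmethyl group, which keeps the carbon count of benzyl on a non-aromatic ring, would separate them. Also open, going by these compounds, is how a phenyl group set directly on the nitrogen, or a short chain such as ethyl, would compare with benzyl.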